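The source may hold more compounds than are shown below. What is called first, only, known or untested is meant among the compounds shown, and "the series" means these compounds.

Within the data shown here, compound 2 `O=S(=O)(c1ccc(F)c(F)c1)c1cnc2c(F)cccc2c1-c1ccccc1F` is one of two compounds measured in an ADME assay on microsomes from liver (Homo sapiens) for metabolic stability, tested at 2.5 uM; a higher number here means faster removal of the compound, a lower number slower removal. In this assay compound 2 gives 1.39 mL/min. Among the measured compounds shown here, the only other measured compound, compound 1 `O=S(=O)(c1ccc(F)c(F)c1)c1cnc2c(F)cccc2c1-c1ccc(F)cc1`, gives 0.78 mL/min in this assay, and the two numbers lie within the usual scatter of each other. For the measured compounds named here, the single measured step, a 1.8-fold higher number from compound 1 to compound 2 (0.25 log units; within the scatter), is the one comparison that bears on the present change, since it too swaps one fluorophenyl for another on the same aromatic carbon. Compound 3 `O=S(=O)(c1ccc(F)c(F)c1)c1cnc2c(F)cccc2c1-c1cccc(F)c1` differs from compound 2 in one place: 3-fluorophenyl in place of 2-fluorophenyl on an aromatic carbon. With the comparable step a 1.8-fold higher number from compound 1 to compound 2 (0.25 log units; within the scatter) staying within the scatter, no step beyond the scatter is expected for this change either. Compound 3 is therefore estimated at 1.1 mL/min in this assay, with a range from 0.5 mL/min to 2.5 mL/min, which corresponds to an expected step of a 1.3-fold lower number from compound 2 to compound 3 (0.10 log units; within the scatter).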

Compound 3, intrinsic clearance in a liver preparation (reported as CLH), per the amount of preparation that the assay uses: 1.28 mL/min
For compound 3 the middle estimate is 1.2-fold (0.07 log units) below the measured one, and the stated range covers the measured number.
By their numbers in this assay, from the lowest: compounds 1, 3 and 2 (each within the scatter of the next).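

In this assay, 3-fluorophenyl in place of 2-fluorophenyl gives a 1.1-fold lower number from compound 2 to compound 3 (0.04 log units; within the scatter), and 3-fluorophenyl in place of 4-fluorophenyl gives a 1.6-fold higher number from compound 1 to compound 3 (0.22 log units; within the scatter). The 2-fluorophenyl, 3-fluorophenyl and 4-fluorophenyl groups can now all be compared on this aromatic carbon, and every step among compound 1, compound 2 and compound 3 stays within the scatter, so this assay does not separate the three placements of the fluorine on the phenyl ring. Nothing shown here explains why the three numbers lie so close together.

Still open, from the compounds shown here alone, is whether a different group on this aromatic carbon, such as a methoxyphenyl, a carboxylic acid or an amine, would give a step beyond the scatter. The compounds shown also cannot tell whether these fluorophenyl swaps would stay as small on a different core.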